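Chloro for bromo on the aromatic carbon: compound 4

The compounds below may be only part of what the source reports. "The series", "measured", "known", "first", "only" and "open" are said of these compounds alone.

Values in a functional assay on A549 cells (Homo sapiens) for antiproliferative activity, read by MTT assay; on this read-out lower numbers stand for stronger inhibition and higher numbers for weaker inhibition:
- compound 1 `O=C1N=C(N2CCC[C@H]2C(=O)Nc2ccc3ncnc(Nc4cccc(Cl)c4)c3c2)S/C1=C/c1cccs1`: 6100 nM
- compound 2 `O=C1N=C(N2CCC[C@H]2C(=O)Nc2ccc3ncnc(Nc4cccc(Cl)c4)c3c2)S/C1=C/c1ccccc1F`: 34500 nM
- compound 3 `O=C1N=C(N2CCC[C@H]2C(=O)Nc2ccc3ncnc(Nc4cccc(Cl)c4)c3c2)S/C1=C/c1ccccc1Br`: a limit of the assay, > 50000 nM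

Compound 3 sits at the assay limit (the limit of > 50000 nM in this assay, at which 1 of the 3 values shown sits), so only a bound is known for it. Against compound 1 the two other compounds show a 5.7-fold higher number from compound 1 to compound 2 (0.75 log units; beyond the scatter) and an at least 8.1-fold higher number from compound 1 to compound 3 (0.91 log units; beyond the scatter). The halogen exchange on the phenyl ring, an at least 1.4-fold higher number from compound 2 to compound 3 (0.16 log units; that floor lies within the scatter), has a floor that stays within the scatter.

Compound 4 `O=C1N=C(N2CCC[C@H]2C(=O)Nc2ccc3ncnc(Nc4cccc(Cl)c4)c3c2)S/C1=C/c1ccccc1Cl` differs from compound 3 by chloro in place of bromo on an aromatic carbon. Going by the values given here, the only measured step bearing on it is the fluoro-to-bromo exchange, whose floor lies within the scatter, so for compound 4 in this assay a step of about an at least 1.1-fold lower number from compound 3 to compound 4 (0.04 log units; that floor lies within the scatter) is expected, with no confident direction. Compound 4 is estimated at 45000 nM, between 15000 nM and 150000 nM, with a fair chance that only a limit is reported again.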

Compound 4, half-maximal inhibitory concentration: > 50000 nM
Compound 4 was reported as a limit (the forecaster's own chance of this, stated with the estimate: 45%); middle value at least 1.1-fold (0.04 log units) from the limit.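

In this assay compound 4 is reported only as a limit, so the 2-chlorophenyl group joins the 2-bromophenyl group at the top of the measurable range: the limit of > 50000 nM in this assay, at which 2 of the 4 values shown sit.

Replacing thiophen-2-yl with 2-chlorophenyl gives an at least 8.1-fold higher number from compound 1 to compound 4 (0.91 log units; beyond the scatter), so the drop seen with the bromo group recurs with chloro. Against the fluoro analogue there is an at least 1.4-fold higher number from compound 2 to compound 4 (0.16 log units; that floor lies within the scatter); the chloro-for-bromo step, with limits at both ends, cannot be read, so no order among the three halogens follows.

Open, as far as these compounds go, is whether an unsubstituted phenyl or a furan-2-yl group would stay near compound 1. The compounds shown cannot separate the halogen's contribution from that of the phenyl ring itself.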